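The source may report more compounds than this note shows. Statements on the series, on what has been measured and on what is new or still open speak of the compounds shown alone.

Measured compounds:
compound 1, `Nc1scc(CN2CCN(c3ccncc3)CC2)c1C(=O)c1ccc(Cl)cc1`: 2%
compound 2, `Nc1scc(CN2CCN(c3cccc(F)c3)CC2)c1C(=O)c1cccc(C(F)(F)F)c1`: 0%
compound 3, `Nc1scc(CN2CCN(c3c(F)cccc3F)CC2)c1C(=O)c1cccc(C(F)(F)F)c1`: 0%

In an assay on CHO cells for displacement of a labelled ligand from adenosine receptor A3 (Homo sapiens), read by scintillation counting, with a stated time of 120 min, tested at 10 uM (a lower number here means less inhibition, a higher number more inhibition at the concentration tested (going by the name of the read-out)), compound 1 gives 2%, the highest of the three numbers shown, though compound 2 and compound 3 both lie within the scatter of it, so the three are not told apart. Compound 4, `Nc1scc(CN2CCN(c3ccc(F)c(Cl)c3)CC2)c1C(=O)c1ccc(Cl)cc1`, differs from compound 1 by 3-chloro-4-fluorophenyl in place of pyridin-4-yl on an amine nitrogen in a ring. For the measured compounds named here, the one measured step that bears on such a swap of the aryl group on the ring nitrogen is no change at the digits printed from compound 2 to compound 3 (within the scatter), and it shows nothing beyond the scatter. Going by the values given here, nothing among the measured compounds points to a gain. Compound 4 is therefore expected to show no change at the digits printed from compound 1 to compound 4 (within the scatter), no step beyond the scatter. The estimate for compound 4 is 2%, with a range from -8% to 14%.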

Compound 4, a percentage reported as inhibition, at one concentration (the size of the read-out at that concentration, not a potency): 0%
Compound 4: middle estimate off by 2 percentage points, on the high side, and the stated range covers the measured number.
By their numbers in this assay, from the lowest: compounds 2, 3, 4 and 1 (each within the scatter of the next).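

In this assay, replacing pyridin-4-yl with 3-chloro-4-fluorophenyl on the ring nitrogen gives a number 2 percentage points lower from compound 1 to compound 4 (within the scatter). The earlier step only exchanged one fluorinated phenyl for another, whereas this one removes the ring's nitrogen and brings in a carbon-only ring carrying chlorine and fluorine, and the number still does not separate from that of compound 1. Nothing available explains this result.

From the compounds shown here alone, whether a benzyl group or a chain ending in a carboxylic acid on that ring nitrogen would lift the number beyond the scatter stays open.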